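The source may report more compounds than this note shows. Statements on the series, on what has been measured and on what is new or still open speak of the compounds shown alone.

Three compounds carry measurement records here: compound 1 (`COC[C@H](C)Oc1cc(Oc2cnc(C(=O)N(C)C)nc2)cc(-c2nccc(=O)[nH]2)c1`), compound 2 (`COC[C@H](C)Oc1cc(Oc2cnc(C(=O)N(C)C)cn2)cc(-c2nccc(=O)[nH]2)c1`) and compound 3 (`Cc1cnc(-c2cc(Oc3ccc(S(=O)(=O)N(C)C)cc3)cc(O[C@@H](C)CO)c2)[nH]c1=O`). In an ADME assay on MDCK-II cells (Canis lupus familiaris) for permeability (on this read-out lower numbers stand for lower permeability and higher numbers for higher permeability), compound 1 gives "not determined" (no result reported), so it offers no number for comparison. In this assay compound 2 gives 2.2 10^-6 cm/s, and compound 3 gives 14 10^-6 cm/s. Compound 3 therefore stands highest of the two numbers, with compound 2 lower by more than the scatter.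

Compound 4 (`CNS(=O)(=O)c1ccc(Oc2cc(O[C@@H](C)CO)cc(-c3ncc(C)c(=O)[nH]3)c2)cc1`) departs from compound 3 in one place, with hydrogen in place of methyl on a sulfonamide nitrogen. Among the measured compounds shown here, no measured pair shows this change on its own, so the data give no direct guide to its size. Compound 3 at 14 10^-6 cm/s sits at the top of the numbers in hand, which makes a fall in this assay the likelier direction. The expected step is a 2.0-fold lower number from compound 3 to compound 4 (0.30 log units; within the scatter), a modest fall close to the edge of the scatter. For compound 4 the estimated value is 7 10^-6 cm/s, with an expected range of 3 10^-6 cm/s to 14 10^-6 cm/s.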

Compound 4, apparent permeability in the MDCK-II assay: 1.6 10^-6 cm/s
Compound 4: middle estimate off by 4.4-fold (0.64 log units), on the high side, and the stated range ends above it.
By their numbers in the MDCK-II assay, from the lowest: compounds 4 and 2 (each within the scatter of the next); then compound 3.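

In the MDCK-II assay compound 3 gives 14 10^-6 cm/s and compound 4 gives 1.6 10^-6 cm/s. Taking one methyl off the sulfonamide nitrogen, so that dimethylsulfamoyl becomes methylsulfamoyl, gives in the MDCK-II assay an 8.8-fold lower number from compound 3 to compound 4 (0.94 log units; beyond the scatter) and offers the first measured view of this position, where this single change produces a step beyond the scatter. In a physicochemical assay for lipophilicity, using the shake flask method (on this read-out lower numbers stand for lower lipophilicity and higher numbers for higher lipophilicity), compound 3 gives 2.26 and compound 4 gives 2.01. In the physicochemical assay the same change gives a number 0.25 log units lower from compound 3 to compound 4 (within the scatter) and so leaves the pair within the scatter of each other on that read-out, while the MDCK-II assay does separate them. Nothing at hand accounts for the size of this step.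

The compounds shown leave open how an ethyl or a cyclopropyl on the sulfonamide nitrogen, or a second hydrogen there in place of the remaining methyl, would read in the MDCK-II assay on this core. They also leave open whether dimethylamino to methylamino on the amide of compound 2 would give a step of like size.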